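A few compounds are considered here, and "the series" means these few. Any claim that something is new, unique, unknown or untested is made for them only; others in the source may bear on it.

Three compounds share a core bearing the methylated urea chain and the acylhydrazone arm. Compound 1 `CN(C(=O)NC(=O)c1cccc(C(F)(F)F)c1)c1nc(C(F)(F)F)c(C(=O)N/N=C/c2cccc(C(F)(F)F)c2)s1` gives 8.16 ug/mL in a functional assay on A549 cells (Homo sapiens) for inhibition, read by MTT assay, with a stated time of 72 h; on this read-out higher numbers stand for weaker inhibition and lower numbers for stronger inhibition. Compound 2 `Cc1nc(N(C)C(=O)NC(=O)c2c(F)cccc2F)sc1C(=O)N/N=C/c1ccc(C(F)(F)F)cc1` gives 60.5 ug/mL in this assay. Compound 3 `CN(C(=O)NC(=O)c1ccccc1F)c1nc(C(F)(F)F)c(C(=O)N/N=C/c2ccc(C(F)(F)F)cc2)s1` gives 5.68 ug/mL in this assay, the lowest of the three numbers, within the scatter of compound 1 and beyond the scatter of compound 2. Compound 4 `CN(C(=O)NC(=O)c1ccc(Cl)cc1Cl)c1nc(C(F)(F)F)c(C(=O)N/N=C/c2ccc(C(F)(F)F)cc2)s1` is not yet measured. The change from compound 3 to compound 4 is 2,4-dichlorophenyl in place of 2-fluorophenyl on a carbonyl carbon. Among the compounds with values here, no measured pair isolates this change, so the step is estimated from compound 3 alone, and the step from compound 3 to compound 4 is expected to stay within the scatter, a 1.1-fold higher number from compound 3 to compound 4 (0.06 log units; within the scatter). Compound 4 is therefore expected to give about 6.5 ug/mL in this assay, between 2.5 ug/mL and 17 ug/mL.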

Compound 4, half-maximal inhibitory concentration: 9.4 ug/mL
Beside the measured number, compound 4's estimate is 1.4-fold (0.16 log units) below it; low and high end bracket the measured number.
By their numbers in this assay, from the lowest: compounds 3, 1 and 4 (each within the scatter of the next); then compound 2.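

Within the data shown here, compound 3 and compound 4 form the only pair here that differs in one place, which gives the series its first direct reading of a change on this carbonyl carbon. In this assay, 2,4-dichlorophenyl in place of 2-fluorophenyl gives a 1.7-fold higher number from compound 3 to compound 4 (0.22 log units; within the scatter), so the added chlorine count and the loss of fluorine leave the number inside the scatter on this one pair. No accompanying measurement bears on this step.

Open, as far as these compounds go, is whether a non-aromatic group on this carbonyl carbon, such as cyclohexyl or an aminoalkyl chain, keeps the number in this range. A single pair also cannot show whether the same change reads alike elsewhere in the series.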